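Tetrazole in place of carboxy on a second core

A few compounds are considered here, and "the series" means these few. Any claim that something is new, unique, unknown or untested is made for them only; others in the source may bear on it.

Compound 1 `COc1cccc2cc(C(=O)O)cnc12` and compound 2 `COc1cccc2cc(-c3nn[nH]n3)cnc12` share one core; compound 3 `Cc1ccc2cc(C(=O)O)cnc2c1C` and compound 4 `Cc1ccc2cc(-c3nn[nH]n3)cnc2c1C` share another. The difference between the two cores is not broken down here. In a functional assay on the whole organism (strain Sprague-Dawley) for inhibition, with Rattus norvegicus as the target (a higher number here means that more compound is needed for the effect, a lower number that less compound is needed), compound 1 gives 25 mg/kg, and compound 2 gives 2.5 mg/kg. The change between them, (2H-tetrazol-5-yl in place of carboxy on an aromatic carbon), gave a 10-fold lower number from compound 1 to compound 2 (1.00 log units; beyond the scatter). In this assay compound 3 gives 25 mg/kg, level with compound 1 at the digits read. Compound 4 carries the same change on its own core: 2H-tetrazol-5-yl in place of carboxy on an aromatic carbon. The two place descriptions agree word for word, so this is the same change, occurring for the second time among these compounds. The only read on it rests on a single pair, so any expectation for compound 4 carries the uncertainty of one example. The step from compound 3 to compound 4 is nonetheless expected to be a 10-fold lower number from compound 3 to compound 4 (1.00 log units; beyond the scatter) because the same change gave a 10-fold lower number from compound 1 to compound 2 (1.00 log units; beyond the scatter). Compound 4 is therefore estimated at 2.5 mg/kg in this assay, with the likely range running from 1 mg/kg to 8 mg/kg.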

Compound 4, minimum effective dose: 1 mg/kg
Compound 4: middle estimate off by 2.5-fold (0.40 log units), on the high side; the measured number falls inside the stated range.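

In this assay, 2H-tetrazol-5-yl in place of carboxy on an aromatic carbon gave a 25-fold lower number from compound 3 to compound 4 (1.40 log units; beyond the scatter), so the direction seen on the first core recurs on the second. The two steps cannot be told apart in size, and the change carries over between these two cores as one effect: the same change on two cores in this assay, a 10-fold lower number (1.00 log units; beyond the scatter) from compound 1 to compound 2 and a 25-fold lower number (1.40 log units; beyond the scatter) from compound 3 to compound 4, 2.5-fold (0.40 log units) apart, within the scatter of two such steps

This rests on two pairs in this assay, so it supports the transfer between these two cores only; it does not show how the change would behave on any other core, nor why the number falls.

Among the compounds shown, this place carries only carboxy or 2H-tetrazol-5-yl, so how a primary amide or a nitrile there would compare remains open. Also open, going by these compounds, is whether the same step would hold on a core carrying an amine or a longer chain, and the separate contribution of the groups that distinguish the two cores is still unresolved.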